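Moving the Thiophene Attachment Point in a Pyridine Series

The source may hold more compounds than are shown below. What is called first, only, known or untested is meant among the compounds shown, and "the series" means these compounds.

Of the compounds shown here, three in this set have been measured in a functional assay on HCT-116 cells (Homo sapiens) for cytotoxicity, with a stated time of 3 days; on this read-out lower numbers stand for stronger inhibition and higher numbers for weaker inhibition. Compound 1 `c1csc(-c2cc(-c3ccoc3)cc(-c3cccs3)n2)c1` gives 50600 nM; compound 2 `Clc1ccc(-c2cc(-c3cccs3)nc(-c3cccs3)c2)o1` gives 95500 nM; compound 3 `Cc1ccsc1-c1cc(-c2ccco2)cc(-c2cccs2)n1` gives 56400 nM. Compound 3 stands second highest of the three numbers; its nearest neighbour is compound 1, whose value lies within the scatter of it, and its furthest is compound 2, also within the scatter. Among the measured compounds shown here, the only single-point step between measured compounds, a 1.9-fold higher number from compound 1 to compound 2 (0.28 log units; within the scatter), exchanges one five-membered ring for another at an aromatic carbon and stays inside the scatter.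

Compound 4 `Cc1ccsc1-c1cc(-c2ccco2)cc(-c2ccsc2)n1` is related to compound 3 by thiophen-3-yl in place of thiophen-2-yl on an aromatic carbon: the thiophene is re-attached through a different ring carbon, next to the ring nitrogen, meta to a 3-methylthiophen-2-yl group and meta to a furan-2-yl group, with no atoms added or removed. For the measured compounds named here, the step from compound 1 to compound 2 is the closest precedent, a swap of one five-membered aromatic ring for another, and it produced nothing beyond the scatter. No larger movement is therefore expected here. Compound 4 is estimated at 60000 nM, with a range of 25000 nM to 150000 nM, which means an expected step of a 1.1-fold higher number from compound 3 to compound 4 (0.03 log units; within the scatter) in this assay.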

Compound 4, half-maximal inhibitory concentration: 51100 nM
Compound 4: the middle estimate sits 1.2-fold (0.07 log units) above what was measured; the measured number falls inside the stated range.
By their numbers in this assay, from the lowest: compounds 1, 4, 3 and 2 (each within the scatter of the next).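

In this assay, the new result gives a 1.1-fold lower number from compound 3 to compound 4 (0.04 log units; within the scatter) for thiophen-3-yl in place of thiophen-2-yl next to the ring nitrogen, so this read-out does not separate the two attachment points of the thiophene at this position. The earlier step, a 1.9-fold higher number from compound 1 to compound 2 (0.28 log units; within the scatter), exchanged one five-membered ring for a different one, whereas this change keeps the same atoms and alters only how they are joined, and it too stays within the scatter. Nothing available here bears on why the two attachment points read alike.

Every compound shown carries only five-membered aromatic rings on the shared core, so it remains open whether an amine, a carboxylic acid or a longer alkyl chain next to the ring nitrogen would move the number beyond the scatter. As far as these compounds go, it is also open whether the same thiophene exchange would read alike if a phenyl ring stood in place of the 3-methylthiophen-2-yl group.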